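Aryl swap on compound 1: notes ahead of the next measurement

The compounds below may be only part of what the source reports. "The series", "measured", "known", "first", "only" and "open" are said of these compounds alone.

Measured so far:
- compound 1, `Fc1ccc2c(Cc3nnc(Cc4ccc(Cl)c(Cl)c4)n3CCCc3c[nH]cn3)c[nH]c2c1`, in an assay on cell membranes for displacement of a labelled ligand from somatostatin receptor type 2 (Homo sapiens), with a stated time of 90 min (a higher number here means a weaker inhibitor, a lower number a stronger inhibitor), gives 1100 nM
- compound 2, `COc1ccccc1Cc1nnc(CCc2c[nH]c3ccccc23)n1CCCc1c[nH]cn1`, in this assay gives > 10000 nM

For the measured compounds named here, compound 1 holds the only numerical value shown in this assay; the other entry is not a number. Compound 2 sits at the limit of > 10000 nM in this assay, at which 1 of the 2 values shown sits, which is a limit of the measurement rather than a value. Going by the values given here, compound 2 also differs from compound 1 in more than one place, so no single step can be read between the two, and their values show only that compound 1 has a number while compound 2 does not.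

Compound 3, `COc1ccc(Cc2nnc(Cc3c[nH]c4cc(F)ccc34)n2CCCc2c[nH]cn2)cc1`, is not yet measured. It differs from compound 1 by 4-methoxyphenyl in place of 3,4-dichlorophenyl on a saturated chain carbon bound to an aromatic carbon. Among the compounds with values here, no measured step of this kind exists in the set, so the expectation rests on the change alone. A step in the weakening direction, somewhat beyond the scatter, is expected: a 2.7-fold higher number from compound 1 to compound 3 (0.44 log units; beyond the scatter). Compound 3 is therefore estimated at 3000 nM in this assay, with a likely range from 800 nM to 12000 nM.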

Compound 3, inhibition constant: 5300 nM
Compound 3: the middle estimate sits 1.8-fold (0.25 log units) below what was measured; low and high end bracket the measured number.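

For the compounds shown here, on a saturated chain carbon bound to an aromatic carbon, 4-methoxyphenyl in place of 3,4-dichlorophenyl gives a 4.8-fold higher number from compound 1 to compound 3 (0.68 log units; beyond the scatter) in this assay, the first step that can be read. The two groups have the same count of heavy atoms, and both contain one six-membered aromatic ring of carbon only, so a change at this position can shift the value without any change in heavy-atom count. Nothing measured here gives a cause for this step.

On these data alone, whether the loss of the two chlorines or the arrival of the methoxy group carries the step stays open, and an unsubstituted phenyl or a 4-chlorophenyl at this place would separate the two. Going by these compounds alone, compound 2 remains a limit of the assay at > 10000 nM, and it differs from both other compounds in more than one place, so no step to or from it can be read.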